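The source may report more compounds than this note shows. Statements on the series, on what has been measured and on what is new or still open speak of the compounds shown alone.

Compound 1 `O=C1Nc2c(ccc(F)c2F)C1(c1ccc(O)cc1)c1ccc(F)cc1`, compound 2 `Cc1ccc(C2(c3ccc(O)cc3)C(=O)Nc3c2ccc(F)c3F)cc1` and compound 3 `Cc1cc(C)c2c(c1)C(c1ccc(O)cc1)(C1CCCCCC1)C(=O)N2` have been measured; compound 4 `Cc1cc(F)cc2c1NC(=O)C2(c1ccc(O)cc1)C1CCCCCC1` has not. In a functional assay on PC-3 cells (Homo sapiens) for cytotoxicity, read by WST assay, with a stated time of 72 h (a lower number here means a stronger inhibitor, a higher number a weaker inhibitor), compound 2 gives 0.8 nM. In this assay compound 1 gives 8.6 nM. The change between them, (fluoro in place of methyl on an aromatic carbon), brings an 11-fold higher number from compound 2 to compound 1 (1.03 log units; beyond the scatter). Compound 3 reaches only a limit of this assay, > 1000 nM, the limit described as the limit of > 1000 nM in this assay, at which 1 of the 3 values shown sits. How the core of compound 3 differs from the core of compound 2 is not broken down here. Compound 4 differs from compound 3 by fluoro in place of methyl on an aromatic carbon, the same kind of change as from compound 2 to compound 1, but on an aromatic carbon that is part of a fused or bridged system of two rings, meta to a fused ring, meta to a methyl group and para to a fused ring, rather than para to a large group. Because compound 3 sits at the limit > 1000 nM and the earlier step weakened the compound, the step from compound 3 to compound 4 is expected to be roughly a step that the limit leaves unreadable from compound 3 to compound 4. Compound 4 is therefore estimated at 3000 nM, between 800 nM and 15000 nM, most likely again reported only as a limit.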

Compound 4, half-maximal inhibitory concentration: > 1000 nM
Compound 4 was reported as a limit (the forecaster's own chance of this, stated with the estimate: 70%); the middle value is on the limit's open side.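

Compound 3 and compound 4 both stand only at a limit of this assay, so no step between them can be read: the limit of > 1000 nM in this assay, at which 2 of the 4 values shown sit.

The compounds shown leave open whether the single difference between compound 3 and compound 4, para to a fused ring, changes the number at all on the core of compound 3.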